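This account rests on a few compounds, and the source may have more. Where it says the series, first, only, none or still open, it means among the compounds named here.

Measured in a functional assay on MCF7 cells (Homo sapiens) for antiproliferative activity, read by CellTiter-Glo, with a stated time of 5 days; a higher number here means a weaker inhibitor, a lower number a stronger inhibitor:
- compound 1 `O=C(O)/C=C/c1ccc(/C(=C(\c2ccc(F)cc2Cl)C2CCC2)c2ccc3nccn3c2)cc1`: 4.4 nM
- compound 2 `N#Cc1ccc(/C(=C(\c2ccc(/C=C/C(=O)O)cc2)c2ccc3nccn3c2)C2CCC2)c(Cl)c1`: 15 nM
- compound 3 `O=C(O)/C=C/c1ccc(/C(=C(\c2ccc(C(F)(F)F)cc2Cl)C2CCC2)c2ccc3nccn3c2)cc1`: 5.1 nM

Compound 2 carries the highest number of the three. The gaps are modest: a 3.4-fold higher number from compound 1 to compound 2 (0.53 log units; beyond the scatter) and a 2.9-fold lower number from compound 2 to compound 3 (0.47 log units; beyond the scatter). The other two compounds sit within the scatter of each other, with a 1.2-fold higher number from compound 1 to compound 3 (0.06 log units; within the scatter).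

The next compound is compound 4 `N#Cc1ccc(/C(=C(\c2ccc(/C=C/C(=O)O)cc2)c2ccc(-c3cncs3)cc2)C2CCC2)c(Cl)c1`. Relative to compound 2, the change is a group of 11 heavy atoms (9 carbon, 1 nitrogen, 1 sulfur; one five-membered aromatic ring with 2 hetero atoms, one six-membered aromatic ring of carbon only) in place of a group of 9 heavy atoms (7 carbon, 2 nitrogen; one five-membered aromatic ring with 2 hetero atoms, one six-membered aromatic ring with 1 hetero atom), on a double-bonded chain carbon bound to an aromatic carbon and a double-bonded chain carbon. The new 4-(1,3-thiazol-5-yl)phenyl group sits on a double-bonded chain carbon bound to an aromatic carbon and a double-bonded chain carbon, and the cyano group of compound 2 stays in place.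

None of the three measured steps touches this position. All of them exchange a single substituent on an aromatic carbon elsewhere in the molecule, so they give only a rough sense of how far values in this small series have moved. Within the data shown here, they offer no direction for the new group, and no compound measured so far carries it. In this assay, no shift beyond the scatter is therefore expected, though with low confidence and a wide range. The expected change is a 1.3-fold higher number from compound 2 to compound 4 (0.12 log units; within the scatter). For compound 4 the estimated value is 20 nM, with an expected range of 6 nM to 70 nM.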

Compound 4, half-maximal inhibitory concentration: 2.9 nM
Estimate against measurement, compound 4: 6.9-fold (0.84 log units) above, outside the stated range (below it).
By their numbers in this assay, from the lowest: compounds 4, 1 and 3 (each within the scatter of the next); then compound 2.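

In this assay, the position on a double-bonded chain carbon bound to an aromatic carbon and a double-bonded chain carbon proves able to move the value: placing 4-(1,3-thiazol-5-yl)phenyl there gives a 5.2-fold lower number from compound 2 to compound 4 (0.71 log units; beyond the scatter). Among these compounds, the earlier steps all exchanged a single substituent on an aromatic carbon, so this is the first measured change at this position, and it shows that the group of 9 heavy atoms in compound 2 can be exchanged for a larger group with a six-membered aromatic ring of carbon only, while compound 4 still gives 2.9 nM. No measurement at hand accounts for this step.

The step changes the ring system and the heavy-atom count together, so the compounds shown leave open how much of it belongs to the 1,3-thiazol-5-yl ring and how much to the phenyl ring, a question that a plain phenyl group or a phenyl carrying an amine at this position would address. They also leave open whether the same gain appears with fluoro or trifluoromethyl in place of the cyano group.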